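The source may report more compounds than this note shows. Statements on the series, on what has been measured and on what is new or still open speak of the compounds shown alone.

Measured so far:
Compound 1, `Cc1ccc(OCC(=O)N(Cc2cccs2)C2COC2)cc1`: 23000 nM
Compound 2, `Cc1ccc(OCC(=O)N(CCO)Cc2cccs2)cc1`: 900 nM

Both were tested in an assay on HEK293 cells for agonist activity at transient receptor potential cation channel subfamily M member 8 (Homo sapiens), read by fluorescence and calcium flux, with a stated time of 15 min; on this read-out higher numbers stand for an effect only at larger amounts of compound and lower numbers for an effect already at smaller amounts. Compound 2 gives the lower of the two numbers: the step of a 26-fold lower number from compound 1 to compound 2 (1.41 log units; beyond the scatter) is large and well beyond the scatter, so compound 2 is the stronger of the two agonists measured here.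

Compound 3, `COCCN(Cc1cccs1)C(=O)COc1ccc(C)cc1`, has not yet been tested. It differs from compound 2 by methyl in place of hydrogen on an oxygen on a saturated carbon, that is, the hydroxy group of the 2-hydroxyethyl chain becomes a methoxy group.

Among the compounds with values here, no measured step covers exactly this change. Within the data shown here, the only step at hand, a 26-fold lower number from compound 1 to compound 2 (1.41 log units; beyond the scatter), swaps the whole group on the amide-type nitrogen and shows that this position matters a great deal. Because the hydroxy group is part of what sets compound 2 apart from compound 1 in a 26-fold lower number from compound 1 to compound 2 (1.41 log units; beyond the scatter), a modest loss of potency is expected for compound 3, though a number within the scatter of compound 2 cannot be ruled out. The expected step is a 2.8-fold higher number from compound 2 to compound 3 (0.44 log units; beyond the scatter), and compound 3 is estimated at 2500 nM, within a range of 700 nM to 10000 nM.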

Compound 3, half-maximal effective concentration: 400 nM
Compound 3: middle estimate off by 6.3-fold (0.80 log units), on the high side; measured number outside the range, below it.
By their numbers in this assay, from the lowest: compound 3; then compound 2; then compound 1.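

In this assay, capping the hydroxy group of the 2-hydroxyethyl chain as a methoxy group costs no potency, and the change gives a 2.3-fold lower number from compound 2 to compound 3 (0.35 log units; beyond the scatter). The hydrogen on that oxygen is therefore not required for activity in this pair, and the hydroxy group alone cannot account for the gap to the oxetan-3-yl compound, as the 2-methoxyethyl chain also gives a 58-fold lower number from compound 1 to compound 3 (1.76 log units; beyond the scatter). Nothing available here explains why the methoxy compound gives the lower number.

Still open, as far as these compounds go, is how far this trend at the amide-type nitrogen extends, for example to a longer chain such as 3-methoxypropyl or to a larger ether such as 2-ethoxyethyl. From the compounds shown here alone, it is equally open whether an amine, as in 2-aminoethyl, would be tolerated on the same nitrogen.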